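Compound 3 to compound 4: a larger carbon ring

The source may report more compounds than this note shows. Statements on the series, on what has been measured and on what is new or still open speak of the compounds shown alone.

Compound 1 `CC(C)(CO)CNC(=O)c1cc2cc(C#N)ccc2n1Cc1cccc(OC(F)(F)F)c1`, compound 2 `CC(C)(O)CCNC(=O)c1cc2cc(C#N)ccc2n1Cc1cccc(OC(F)(F)F)c1` and compound 3 `N#Cc1ccc2c(c1)cc(C(=O)NCCC1(O)CCC1)n2Cc1cccc(OC(F)(F)F)c1` share one core and differ in the group on a saturated chain carbon bound to an amide-type nitrogen. In an in vitro ADME assay on microsomes from Gut (Homo sapiens) for metabolic stability, using NADPH (on this read-out higher numbers stand for fast clearance and lower numbers for slow clearance), compound 1 gives < 6 mL.min-1.g-1, which is a limit of the assay. In this assay compound 2 gives < 6 mL.min-1.g-1, also a limit. In this assay compound 3 gives < 6 mL.min-1.g-1, again a limit and not a number. The series therefore stands entirely at the limit of < 6 mL.min-1.g-1 in this assay, at which 3 of the 3 values shown sit.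

Compound 4 `CC(O)C1(CNC(=O)c2cc3cc(C#N)ccc3n2Cc2cccc(OC(F)(F)F)c2)CCCC1` departs from compound 3 in one place: a group of 8 heavy atoms (7 carbon, 1 oxygen; one five-membered non-aromatic ring of carbon only) in place of a group of 6 heavy atoms (5 carbon, 1 oxygen; one four-membered non-aromatic ring of carbon only), on a saturated chain carbon bound to an amide-type nitrogen. The measured steps that bear on this change are a step that the two limits leave unreadable from compound 1 to compound 3 and a step that the two limits leave unreadable from compound 2 to compound 3. Neither offers a size to carry over, so no step beyond the scatter is expected in this assay. The expected step is a step that the limit leaves unreadable from compound 3 to compound 4. The expectation rests on compound 3, whose limit is < 6 mL.min-1.g-1. For compound 4 the estimated value is 5 mL.min-1.g-1, with an expected range from 3 mL.min-1.g-1 to 12 mL.min-1.g-1.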

Compound 4, intrinsic clearance in microsomes: 99 mL.min-1.g-1
The estimate for compound 4 lay 20-fold (1.30 log units) below the measured number, outside the stated range (above it).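

In this assay, going by these compounds alone, this position turns out to tolerate far less than the earlier compounds suggested: the group with one five-membered non-aromatic ring of carbon only, in place of (1-hydroxycyclobutyl)methyl, gives an at least 16-fold higher number from compound 3 to compound 4 (1.21 log units; beyond the scatter), and against the groups with no ring the result is an at least 16-fold higher number from compound 2 to compound 4 (1.21 log units; beyond the scatter) and an at least 16-fold higher number from compound 1 to compound 4 (1.21 log units; beyond the scatter). The hydrogen-bond donor and acceptor counts are the same in the leaving and entering groups, so those counts do not track this change. The steps among compound 1, compound 2 and compound 3 cannot be read, and only compound 4 gives this position a number: the limit of < 6 mL.min-1.g-1 in this assay, at which 3 of the 4 values shown sit.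

The compounds shown do not separate the ring size from the other differences between the two groups. They also leave open how a six-membered carbon ring, or an amine on the same chain, would read in this assay.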